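Shortening the Ether Chain: From Compound 3 to Compound 4

The compounds below may be only part of what the source reports. "The series", "measured", "known", "first", "only" and "open" are said of these compounds alone.

Of the compounds shown here, three sharing one core have been tested in an assay on isolated protein for inhibition of Aromatase (Homo sapiens), read by fluorescence, with stated times of 10 min and 60 min; a higher number here means a weaker inhibitor, a lower number a stronger inhibitor. Compound 3 `CCC#CCOc1ccc(C(=O)c2ccc(Cn3ccnc3)cc2)cc1` gives 1430 nM, the highest number of the three. Its nearest neighbour is compound 1 `C#CCOc1ccc(C(=O)c2ccc(Cn3ccnc3)cc2)cc1`, which gives 210 nM in this assay, and the furthest is compound 2 `COc1ccc(C(=O)c2cccc(Cn3ccnc3)c2)cc1`, which gives 13 nM.

Going by the values given here, the only single-change step among the measured compounds runs from compound 1 to compound 3: a 6.8-fold higher number from compound 1 to compound 3 (0.83 log units; beyond the scatter). Growing the chain on the ether oxygen therefore cost potency.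

Compound 4 `CCCOc1ccc(C(=O)c2ccc(Cn3ccnc3)cc2)cc1` has not yet been measured. It differs from compound 3 in one place: ethyl in place of but-1-yn-1-yl on a saturated chain carbon bound to an oxygen on an aromatic ring. Read one bond further out, the (pent-2-yn-1-yl)oxy chain becomes propoxy, so the chain is shorter and the triple bond is gone.

Among the compounds with values here, since lengthening the chain weakened compound 3 relative to compound 1, shortening it again is expected to move the number back down, though the loss of the triple bond has no measured counterpart here. The step expected from compound 3 to compound 4 in this assay is a 5.7-fold lower number from compound 3 to compound 4 (0.76 log units; beyond the scatter). Compound 4 is therefore estimated at 250 nM, within a range of 70 nM to 900 nM.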

Compound 4, half-maximal inhibitory concentration: 374 nM
Beside the measured number, compound 4's estimate is 1.5-fold (0.17 log units) below it; the range from low to high includes it.
By their numbers in this assay, from the lowest: compound 2; then compounds 1 and 4 (each within the scatter of the next); then compound 3.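

In this assay, replacing the (pent-2-yn-1-yl)oxy chain with propoxy gives a 3.8-fold lower number from compound 3 to compound 4 (0.58 log units; beyond the scatter), so much of the potency lost on growing the chain returns at this position even though the triple bond has gone. Putting ethyl in place of ethynyl on the same saturated chain carbon gives a 1.8-fold higher number from compound 1 to compound 4 (0.25 log units; within the scatter), which means that among these compounds the triple bond makes no readable difference when the chain is this short, and the weak result belongs to the pent-2-yn-1-yl chain rather than to every chain with a triple bond. No separate evidence bears on why these chains rank in this order.

Going by these compounds, what stays open is whether a saturated pentyl chain would behave like the weak pent-2-yn-1-yl chain or like the shorter propyl chain, which is the comparison needed to separate chain length from the triple bond at the longer size. Also open, on these data alone, is how this position would respond to a chain ending in something other than plain carbon, such as an amine or a carboxylic acid.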